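The source may hold more compounds than are shown below. What is called first, only, known or untested is meant among the compounds shown, and "the series" means these compounds.

Among the measured compounds shown here, compound 2 `CCCCCCCCC(=O)N1c2ccccc2CCC1C(=O)Nc1ccccc1C(F)(F)F` is the only compound of the pair for which a functional assay on NUGC-3 cells (Homo sapiens) for cytotoxicity, read by sulforhodamine B assay, with a stated time of 72 h (a lower number here means a stronger inhibitor of growth, a higher number a weaker inhibitor of growth), returns a number: in this assay compound 2 gives 6180 nM. Compound 1 `CCCC(=O)N1c2ccccc2CCC1C(=O)Nc1ccccc1C(F)(F)F` differs from it only in the length of the acyl chain on the ring nitrogen. In this assay compound 1 gives > 70000 nM, which is a limit of the assay rather than a number, namely (the limit of > 70000 nM in this assay, at which 1 of the 2 values shown sits). For the measured compounds named here, the single measured step therefore runs from compound 1 to compound 2, with pentyl in place of hydrogen on a saturated chain carbon, three bonds along the chain from a carbonyl carbon, and it yields an at least 11-fold lower number from compound 1 to compound 2 (1.05 log units; beyond the scatter). Compound 3 `O=C(Nc1ccccc1C(F)(F)F)C1CCc2ccccc2N1` has not yet been measured. It differs from compound 2 by hydrogen in place of octylcarbonyl on a nitrogen on an aromatic ring in a ring, so the acyl group that was lengthened in the measured step is now absent altogether. Since the shorter chain sat at the limit while the longer one gave a number, removing the chain entirely is expected to move the number back toward weaker growth inhibition, by a 6.5-fold higher number from compound 2 to compound 3 (0.81 log units; beyond the scatter). In this assay compound 3 is expected to give about 40000 nM, within 8000 nM to 100000 nM, with a real chance that only a limit is reported.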

Compound 3, concentration for 50% growth inhibition: 39300 nM
Beside the measured number, compound 3's estimate is 1.0-fold (0.01 log units) above it; the measured number falls inside the stated range.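

Among the compounds shown here, replacing the whole acyl group gives the first reading of this nitrogen with nothing on it, and in this assay hydrogen in place of octylcarbonyl gives a 6.4-fold higher number from compound 2 to compound 3 (0.80 log units; beyond the scatter), so the long chain accounts for a real but modest part of the growth inhibition seen with the shared core. Compound 1 is reported only as a limit, not as a number: the limit of > 70000 nM in this assay, at which 1 of the 3 values shown sits. The remaining step, an at least 1.7-fold lower number from compound 1 to compound 3 (0.25 log units; that floor lies within the scatter), therefore does not put propylcarbonyl and hydrogen at this nitrogen in order, and of the two acyl groups shown, only octylcarbonyl stands clearly apart from the bare nitrogen.

The compounds shown leave open how the number changes with chains of intermediate length, with a chain longer than octylcarbonyl, or with a benzoyl group on this nitrogen. They also leave open whether the trifluoromethyl group, which stays constant throughout, could give way to a chlorine or a nitrile without changing the number.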